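The compounds below may be only part of what the source reports. "The series", "measured", "known", "first", "only" and "open" are said of these compounds alone.

Compound 1 `CC(C)(C)Sc1c(CC(C)(C)C(=O)O)n(Cc2ccc(Cl)cc2)c2ccc(OCc3ccc4cc(F)c(F)cc4n3)cc12`: in a functional assay for inhibition, with Homo sapiens as the target (a lower number here means a stronger inhibitor, a higher number a weaker inhibitor), compound 1 gives 7 nM.
Compound 2 `CC(C)(C)Sc1c(CC(C)(C)C(=O)O)n(Cc2ccc(Cl)cc2)c2ccc(OCc3cc4ccccc4cn3)cc12`: in this assay compound 2 gives 3 nM.
Compound 3 `CC(C)(C)Sc1c(CC(C)(C)C(=O)O)n(Cc2ccc(Cl)cc2)c2ccc(OCc3ccncc3)cc12`: not yet measured.

Compound 2 holds the lowest of the two numbers, the step being a 2.3-fold lower number from compound 1 to compound 2 (0.37 log units; beyond the scatter). Compound 3 differs from compound 2 by pyridin-4-yl in place of isoquinolin-3-yl on a saturated chain carbon bound to an oxygen on an aromatic ring. Within the data shown here, the one measured step swapped one group for another at the same place and was modest; no measured step removes part of that group, so it bears only loosely here. A loss of inhibition is expected, so compound 3 is estimated at 40 nM, between 8 nM and 300 nM. That corresponds to an expected step of a 13-fold higher number from compound 2 to compound 3 (1.12 log units; beyond the scatter).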

Compound 3, half-maximal inhibitory concentration: 6 nM
The estimate for compound 3 lay 6.7-fold (0.82 log units) above the measured number, outside the stated range (below it).
By their numbers in this assay, from the lowest: compounds 2, 3 and 1 (each within the scatter of the next, the first and the last beyond it).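

In this assay, replacing isoquinolin-3-yl with pyridin-4-yl on the saturated chain carbon removes the carbon-only aromatic ring and gives a 2.0-fold higher number from compound 2 to compound 3 (0.30 log units; within the scatter), so that ring is not needed for strong inhibition in this series. The much smaller group of compound 3 also holds up against the fluorine-bearing two-ring group of compound 1, with a 1.2-fold lower number from compound 1 to compound 3 (0.07 log units; within the scatter). No measurement here accounts for this tolerance.

The compounds shown leave open whether the ring nitrogen is needed, which a plain phenyl ring would test. On these data alone, whether a non-aromatic group such as a dimethylamino group would serve here also remains open.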